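A few compounds are considered here, and "the series" means these few. Any claim that something is new, unique, unknown or untested is made for them only; others in the source may bear on it.

In a functional assay on Jurkat cells (Homo sapiens) (on this read-out lower numbers stand for stronger inhibition and higher numbers for weaker inhibition), two compounds sharing one core have been tested so far. Compound 1 `CC(C)[C@H](NC(=O)COc1cccc2ccccc12)C(=O)N[C@@H](CC(=O)O)C(=O)COc1cccc(C(F)(F)F)c1`, with a 3-(trifluoromethyl)phenyl group, gives > 100000 nM, which is a limit of the assay and not a number. Compound 2 `CC(C)[C@H](NC(=O)COc1cccc2ccccc12)C(=O)N[C@@H](CC(=O)O)C(=O)COc1ccc(F)cc1`, with 4-fluorophenyl in its place, gives > 100000 nM, which is again only a limit. The data so far amount to the limit of > 100000 nM in this assay, at which 2 of the 2 values shown sit. Compound 2 therefore has no number of its own to start from.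

Compound 3 `CC(C)[C@H](NC(=O)COc1cccc2ccccc12)C(=O)N[C@@H](CC(=O)O)C(=O)COc1ccc(F)cc1F` adds fluoro in place of hydrogen on an aromatic carbon, turning 4-fluorophenyl into 2,4-difluorophenyl: fluoro in place of hydrogen on an aromatic carbon. The new fluoro sits ortho to a large group and meta to the existing fluoro group.

For the measured compounds named here, only one measured step bears on this change, a step that the two limits leave unreadable from compound 1 to compound 2, and it has no size that can be used as a guide. No clear step is therefore expected in this assay, although some measurable inhibition cannot be ruled out. The expected outcome is a number no higher from compound 2 to compound 3 (the limit leaves the size open). For compound 3 the estimate is 100000 nM, with an expected range from 30000 nM to 200000 nM.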

Compound 3, half-maximal inhibitory concentration: 33200 nM
The estimate for compound 3 lay 3.0-fold (0.48 log units) above the measured number, and the stated range covers the measured number.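

In this assay, fluoro on an aromatic carbon ortho to a large group gives an at least 3.0-fold lower number from compound 2 to compound 3 (0.47 log units; beyond the scatter), which shows that this position on the ring can change the read-out by more than the usual scatter. Replacing the whole aryl group, with 2,4-difluorophenyl in place of 3-(trifluoromethyl)phenyl, gives an at least 3.0-fold lower number from compound 1 to compound 3 (0.47 log units; beyond the scatter), whereas the step between the two earlier compounds cannot be read. Compound 3 is the only compound so far with a number of its own, so both readable steps give only a minimum size, and the other two compounds remain at a limit of the assay: the limit of > 100000 nM in this assay, at which 2 of the 3 values shown sit.

The compounds shown leave open whether the effect belongs to fluoro itself or whether another small group at this position, such as chloro, methyl or methoxy, would lower the number further. They also leave open whether the new fluoro has the same effect without the existing fluoro group, and how much further inhibition this part of the core can give.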